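Estimating Compound 4 from Sparse Cytotoxicity Data

The source may hold more compounds than are shown below. What is called first, only, known or untested is meant among the compounds shown, and "the series" means these compounds.

Three compounds have been tested in a functional assay on HCT-116 cells (Homo sapiens) for cytotoxicity, read by MTT assay, with a stated time of 3 days; a lower number here means a stronger inhibitor, a higher number a weaker inhibitor:

compound 1, `CN(C)Cc1ccc(/C=N/Nc2ncnc3sc(C(C)(C)C)cc23)cc1`, 0.128 ug/mL
compound 2, `CNCc1ccc(/C=N/Nc2ncnc3sc(C(C)(C)C)cc23)cc1`, 0.056 ug/mL
compound 3, `COC(=O)c1ccc(/C=N/Nc2ncnc3sc(C(C)(C)C)cc23)cc1`, "not determined" (no result reported)

All three share one core and differ only in the group attached to one six-membered aromatic ring of carbon only. Within the data shown here, the single step that can be read, a 2.3-fold lower number from compound 1 to compound 2 (0.36 log units; beyond the scatter), arises from hydrogen in place of methyl on an amine nitrogen. Compound 3 itself stands nowhere on the numbers: its outcome in this assay is "not determined" (no result reported), so there is no starting value to build from.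

Compound 4, `CN(C)S(=O)(=O)c1ccc(/C=N/Nc2ncnc3sc(C(C)(C)C)cc23)cc1`, differs from compound 3 by dimethylsulfamoyl in place of methoxycarbonyl on an aromatic carbon. Among the measured compounds shown here, neither compound 1 nor compound 2 carries a group of this kind, and the one measured step concerns an amine rather than the kind of group exchanged here, so it does not bear on this change. For the measured compounds named here, with no anchor, the only guide is the span covered by compound 1 and compound 2, which carry their groups on the same ring. Compound 4 is therefore estimated at 0.3 ug/mL, with a range from 0.05 ug/mL to 2 ug/mL, wide enough to admit a result on either side of those two compounds, and no direction can be given.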

Compound 4, half-maximal inhibitory concentration: 1.42 ug/mL
Compound 4: the middle estimate sits 4.7-fold (0.68 log units) below what was measured; the range from low to high includes it.
By their numbers in this assay, from the lowest: compound 2; then compound 1; then compound 4.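

In this assay, among these compounds, the aromatic carbon that held the amine-bearing groups of the earlier compounds also accepts dimethylsulfamoyl and still gives a measured number, but that number is much higher: the exchange for (methylamino)methyl is a 25-fold higher number from compound 2 to compound 4 (1.40 log units; beyond the scatter) and the exchange for (dimethylamino)methyl is an 11-fold higher number from compound 1 to compound 4 (1.05 log units; beyond the scatter) on the same carbon. Both steps are large and beyond the scatter, so replacing the whole group at this place moves the number far more than the modest change on the amine nitrogen seen earlier, and among these three compounds the two carrying an amine sit lowest. Nothing measured here gives a reason for this rise.

Going by these compounds, compound 3 has no result, so the direct exchange of methoxycarbonyl for dimethylsulfamoyl cannot be read, and the effect of that ester on this position remains unknown. On these data alone, it also remains open whether a plain aminomethyl group would give a number near those of the two amine compounds, and where a carboxylic acid on this same carbon would fall.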